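Replacing a substituted benzyl with a phenoxymethyl on the amide

A few compounds are considered here, and "the series" means these few. Any claim that something is new, unique, unknown or untested is made for them only; others in the source may bear on it.

Compound 2 `CC(C)C[C@H](N)c1cc(C(F)(F)F)ccc1N1CCN(C(=O)C(C)Cc2ccc(Cl)cc2O)CC1` and compound 1 `CC(C)C[C@H](N)c1cc(C(F)(F)F)ccc1N1CCN(C(=O)C(C)Cc2ccc(Cl)cc2)CC1` share a core and differ only in a hydroxy on an aromatic carbon. Among the compounds with values here, in an assay on HEK293 cells for displacement of a labelled ligand from Melanocortin receptor 4 (Homo sapiens) (on this read-out higher numbers stand for weaker inhibition and lower numbers for stronger inhibition), compound 2 gives 36 nM, the lower of the two numbers so far, while compound 1 gives 47 nM; the step of a 1.3-fold lower number from compound 1 to compound 2 (0.12 log units; within the scatter) is within the scatter, so the two cannot be ordered. Compound 3 `CC(C)C[C@H](N)c1cc(C(F)(F)F)ccc1N1CCN(C(=O)COc2ccc(Cl)cc2)CC1` is built from compound 2 by the change ((4-chlorophenoxy)methyl in place of 1-(4-chloro-2-hydroxybenzyl)ethyl on a carbonyl carbon). Within the data shown here, the only measured step that bears on it is a 1.3-fold lower number from compound 1 to compound 2 (0.12 log units; within the scatter), which shows that the hydroxy that leaves adds nothing beyond the scatter. Among the measured compounds shown here, the rest of the change, a shorter group with an oxygen in the chain in place of the branched benzyl, has no measured counterpart, so the direction is open and the uncertainty wide. On that footing a modest weakening is expected, the step of a 2.2-fold higher number from compound 2 to compound 3 (0.35 log units; beyond the scatter) being the estimate, and compound 3 is expected to give 80 nM in this assay, within a range from 20 nM to 320 nM.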

Compound 3, inhibition constant: 2900 nM
For compound 3 the middle estimate is 36-fold (1.56 log units) below the measured one, and the stated range ends below it.
By their numbers in this assay, from the lowest: compounds 2 and 1 (each within the scatter of the next); then compound 3.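

In this assay, the position on the carbonyl carbon whose other neighbour is the amide-type nitrogen in a ring proves highly sensitive to this change, with an 81-fold higher number from compound 2 to compound 3 (1.91 log units; beyond the scatter) and a 62-fold higher number from compound 1 to compound 3 (1.79 log units; beyond the scatter), whereas the hydroxy step, a 1.3-fold lower number from compound 1 to compound 2 (0.12 log units; within the scatter), showed no such sensitivity. Compound 1 carries no hydroxy, and its step is also large. The loss of that hydroxy cannot account for the result on its own; the large step remains when 1-(4-chlorobenzyl)ethyl is replaced by (4-chlorophenoxy)methyl, even though the chlorine-bearing aromatic ring stays in the entering group. Nothing available here explains the size of this step.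

The change removes the branch, places an oxygen in the chain and shortens the group all at once, so the compounds shown do not separate these parts. Going by these compounds, a 1-(4-chlorophenoxy)ethyl group, which has the oxygen and a branch, or an unbranched 2-(4-chlorophenyl)ethyl group, which has no oxygen, could show which part carries the step, and whether either would read closer to compound 1 or to compound 3 remains open.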